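Fluoro to methoxy on an indole-type series in HeLa cells

A few compounds are considered here, and "the series" means these few. Any claim that something is new, unique, unknown or untested is made for them only; others in the source may bear on it.

Measured compounds:
compound 1 `COc1ccc(-c2cc(C(C)=O)c3[nH]c(-c4ccccc4)cc3c2)cc1` 15500 nM
compound 2 `COc1ccc(-c2cc(C(C)=O)c3[nH]c(-c4ccc(F)cc4)cc3c2)cc1` 9460 nM
compound 3 `COc1ccc(-c2cc3cc(-c4ccc(F)cc4)cc(C(C)=O)c3[nH]2)cc1` 42800 nM

In a functional assay on HeLa cells (Homo sapiens) for cytotoxicity, read by MTT assay, with a stated time of 2 days (a higher number here means that more compound is tolerated, a lower number that less compound is tolerated), compound 3 gives the highest number of the three. Compound 1 stands nearest to it, and compound 2 furthest; both gaps lie beyond the scatter, so compound 3 is the best tolerated of the measured set.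

The unmeasured compound 4 `COc1ccc(-c2cc(C(C)=O)c3[nH]c(-c4ccc(OC)cc4)cc3c2)cc1` differs from compound 3 by methoxy in place of fluoro on an aromatic carbon, which amounts to 4-fluorophenyl becoming 4-methoxyphenyl.

Among the compounds with values here, only one single-point step is available for comparison: a 1.6-fold lower number from compound 1 to compound 2 (0.21 log units; within the scatter), which concerns a different position and a different exchange. Within the data shown here, no measured pair exchanges fluoro for methoxy, so the step from compound 3 to compound 4 has no direct precedent. Given that the only nearby step stayed within the scatter, a shift of similar modest size is expected here, with no confident direction.

Compound 4 is therefore estimated at 30000 nM, within a range of 12000 nM to 75000 nM, corresponding to an expected step of a 1.4-fold lower number from compound 3 to compound 4 (0.15 log units; within the scatter).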

Compound 4, concentration lethal to 50% of the cells: 7130 nM
The estimate for compound 4 lay 4.2-fold (0.62 log units) above the measured number, outside the stated range (below it).
By their numbers in this assay, from the lowest: compounds 4, 2 and 1 (each within the scatter of the next, the first and the last beyond it); then compound 3.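

In this assay, methoxy in place of fluoro on the 4-fluorophenyl group of compound 3 gives a 6.0-fold lower number from compound 3 to compound 4 (0.78 log units; beyond the scatter), so this change at this place moves the number well beyond the scatter. The same exchange on the 4-fluorophenyl group of compound 2, which sits at a different place on the shared core, gives a 1.3-fold lower number from compound 2 to compound 4 (0.12 log units; within the scatter), so among these compounds the outcome depends on where the exchange is made and not on the exchange alone. At that second place, methoxy in place of hydrogen gives a 2.2-fold lower number from compound 1 to compound 4 (0.34 log units; beyond the scatter), a step beyond the scatter, whereas fluoro in place of hydrogen gives a 1.6-fold lower number from compound 1 to compound 2 (0.21 log units; within the scatter), which stays within it.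

On these data alone, whether an amine, a hydroxyl group or a longer chain such as ethoxy at either place would behave like methoxy or like fluoro remains open. Nothing in the data shown explains why the same exchange gives such different steps at the two places.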